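Thiocarbonyl for carbonyl on the ring amine of compound 1

The compounds below may be only part of what the source reports. "The series", "measured", "known", "first", "only" and "open" are said of these compounds alone.

Compound 1, `CCCC(=O)N1CCC(CN2CC[C@H](NC(=O)c3cc(Cl)c(N)cc3OC)[C@H](OC)C2)CC1`, gives 178 nM in an assay on COS-7 cells for displacement of a labelled ligand from 5-hydroxytryptamine receptor 4 (Homo sapiens), read by scintillation counting, with a stated time of 30 min (on this read-out lower numbers stand for stronger inhibition and higher numbers for weaker inhibition), the lowest of the three numbers measured. Compound 2, `CCOC(=O)N1CCC(CN2CC[C@H](NC(=O)c3cc(Cl)c(N)cc3OC)[C@H](OC)C2)CC1`, gives 377 nM, and compound 3, `COc1cc(N)c(Cl)cc1C(=O)N[C@H]1CCN(CC2CCN(C(C)=O)CC2)C[C@H]1OC`, gives 592 nM. Both steps away from compound 1 raised the number: a 2.1-fold higher number from compound 1 to compound 2 (0.33 log units; beyond the scatter) and a 3.3-fold higher number from compound 1 to compound 3 (0.52 log units; beyond the scatter), while a 1.6-fold higher number from compound 2 to compound 3 (0.20 log units; within the scatter).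

Compound 4, `CCC(=S)N1CCC(CN2CC[C@H](NC(=O)c3cc(Cl)c(N)cc3OC)[C@H](OC)C2)CC1`, differs from compound 1 in one place: a group of 4 heavy atoms (3 carbon, 1 sulfur; no ring) in place of a group of 5 heavy atoms (4 carbon, 1 oxygen; no ring), on an amine nitrogen in a ring, on an amine nitrogen in a ring of a six-membered non-aromatic ring with 1 nitrogen. The step shortens the chain by one carbon and puts sulfur where oxygen stood. Going by the values given here, the two measured steps that bear on it, from compound 1 to compound 2 and from compound 1 to compound 3, both gave modest higher numbers when the propylcarbonyl group was altered, so a modest rise in this assay is expected here too, though the exchange of oxygen for sulfur has no measured precedent. Compound 4 is therefore expected to give about 300 nM, within 120 nM to 800 nM, a step of a 1.7-fold higher number from compound 1 to compound 4 (0.23 log units; within the scatter).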

Compound 4, half-maximal inhibitory concentration: 593 nM
Compound 4: middle estimate off by 2.0-fold (0.30 log units), on the low side, within the range that was stated.
By their numbers in this assay, from the lowest: compound 1; then compounds 2, 3 and 4 (each within the scatter of the next).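

In this assay, the thiocarbonyl group joins the other replacements on the ring amine nitrogen in standing apart from propylcarbonyl (a 3.3-fold higher number from compound 1 to compound 4 (0.52 log units; beyond the scatter)), so compound 1 remains separated from all three other compounds by more than the scatter. The new group cannot be told apart from those in the other two compounds (a 1.0-fold higher number from compound 3 to compound 4 (0.00 log units; within the scatter); a 1.6-fold higher number from compound 2 to compound 4 (0.20 log units; within the scatter)), so the sulfur-bearing group, the ethoxy-bearing group and the shortest acyl group shown all read alike at this position. No measurement at hand accounts for this result.

The step changes the chain and puts sulfur in place of oxygen together, leaving open how much each contributes, which a thiocarbonyl carrying a propyl chain could separate. Also open, from the compounds shown here alone, is whether a butyl chain on the carbonyl, or a dimethylamino group there, would read like compound 1 or like the other three.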